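Working notes: expected solubility of compound 4

This account rests on a few compounds, and the source may have more. Where it says the series, first, only, none or still open, it means among the compounds named here.

Three members of the series have a number in a physicochemical assay for solubility, with a stated time of 24 h, at pH 3; on this read-out lower numbers stand for lower solubility and higher numbers for higher solubility. Compound 1 `CC(=O)N1CCC(c2nc(NCc3ccccn3)ncc2-c2cc(C)no2)CC1` gives 221000 nM and compound 3 `CC(=O)N1CCC(c2nc(N3CCN(C)CC3)ncc2-c2cc(C)no2)CC1` gives 225000 nM. Compound 2 `Cc1cc(-c2cnc(N3CCN(C)CC3)nc2-c2ccc(C)s2)on1` gives 11000 nM, the lowest of the three, with both other numbers beyond the scatter above it. The step of a 20-fold higher number from compound 2 to compound 3 (1.31 log units; beyond the scatter) is large, whereas a 1.0-fold higher number from compound 1 to compound 3 (0.01 log units; within the scatter) shows that exchanging the same two groups on the shared core makes no difference beyond the scatter.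

Compound 4 `Cc1cc(-c2cnc(NCc3ccccn3)nc2-c2ccc(C)s2)on1` is not yet measured in this assay. It differs from compound 2 by ((pyridin-2-yl)methyl)amino in place of 4-methylpiperazin-1-yl on an aromatic carbon. This is the exchange seen between compound 1 and compound 3, taken in the reverse direction, on a core that carries the 5-methylthiophen-2-yl group instead of the 1-acetylpiperidin-4-yl group. Among the compounds with values here, the one measured step that bears on it, a 1.0-fold higher number from compound 1 to compound 3 (0.01 log units; within the scatter), lies within the scatter, so for compound 4 a step of no more than the scatter is expected in this assay, in either direction. Whether the exchange behaves the same way on the core of compound 2 cannot be checked from the other two compounds. For compound 4 the expected number is 11000 nM, with a range from 4500 nM to 27000 nM. This amounts to an expected step of no change at the digits printed from compound 2 to compound 4 (within the scatter).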

Compound 4, solubility: 1000 nM
The estimate for compound 4 lay 11-fold (1.04 log units) above the measured number; the measured number lies below the stated range.
By their numbers in this assay, from the lowest: compound 4; then compound 2; then compounds 1 and 3 (each within the scatter of the next).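

In this assay, the exchange on the aromatic carbon between two ring nitrogen atoms turns out to depend on the rest of the molecule: with the 5-methylthiophen-2-yl group present, ((pyridin-2-yl)methyl)amino in place of 4-methylpiperazin-1-yl gives an 11-fold lower number from compound 2 to compound 4 (1.04 log units; beyond the scatter), while the reverse exchange with the 1-acetylpiperidin-4-yl group present gives a 1.0-fold higher number from compound 1 to compound 3 (0.01 log units; within the scatter). The exchange of those two groups on the other position is large with either group here, as a 220-fold lower number from compound 1 to compound 4 (2.34 log units; beyond the scatter) with ((pyridin-2-yl)methyl)amino and, in the reverse sense, a 20-fold higher number from compound 2 to compound 3 (1.31 log units; beyond the scatter) with 4-methylpiperazin-1-yl. Nothing available explains why the two positions fail to act independently in these four compounds.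

On these data alone, it remains open whether the lower number of compound 4 goes with the six-membered aromatic ring of the entering group or with its hydrogen-bond donor. A benzylamino or a morpholin-4-yl group at this position on the core of compound 2 would help separate these, and a phenyl group in place of 5-methylthiophen-2-yl would show how far the dependence extends beyond that group.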